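The source may report more compounds than this note shows. Statements on the series, on what has been measured and on what is new or still open speak of the compounds shown alone.

Of the two compounds measured in an assay on HEK293 cells for agonist activity at Toll-like receptor 8 (Homo sapiens), read by spectrophotometry (a higher number here means that more compound is needed for the effect, a lower number that less compound is needed), compound 2 `CCCCCc1c(C)nc(N)nc1NCCCC` gives 1220 nM, the lower of the two numbers. Compound 1 `CCCCNc1nc(N)nc(C)c1C#CCN1CCCCC1` gives 3790 nM in this assay, a higher number that lies beyond the usual scatter. Compound 3 `C#Cc1c(C)nc(N)nc1NCCCC` is not yet measured; it differs from compound 2 in a single place: ethynyl in place of pentyl on an aromatic carbon. Among the measured compounds shown here, no step between measured compounds covers this kind of change, so the expectation rests on little. The number is expected to rise moderately, as estimated in a 2.5-fold higher number from compound 2 to compound 3 (0.39 log units; beyond the scatter). Compound 3 is thus expected to give 3000 nM, within a range from 800 nM to 12000 nM.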

Compound 3, half-maximal effective concentration: 4900 nM
Compound 3: the middle estimate sits 1.6-fold (0.21 log units) below what was measured; low and high end bracket the measured number.
By their numbers in this assay, from the lowest: compound 2; then compounds 1 and 3 (each within the scatter of the next).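

In this assay, the aromatic carbon that carries pentyl in compound 2 proves responsive to its substituent: ethynyl in place of pentyl gives a 4.0-fold higher number from compound 2 to compound 3 (0.60 log units; beyond the scatter). At the far end of the triple bond, hydrogen in place of (piperidin-1-yl)methyl gives a 1.3-fold higher number from compound 1 to compound 3 (0.11 log units; within the scatter), so this pair separates no effect of that group. No evidence is at hand on why either step has this size. From the compounds shown here alone, it remains open whether a propyl group or a chain longer than pentyl on the aromatic carbon would give a lower number than compound 2. Going by these compounds, it also remains open whether a phenyl ring or a primary amine on the triple-bonded carbon would move the number at all.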